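The source may hold more compounds than are shown below. What is called first, only, known or untested is meant among the compounds shown, and "the series" means these compounds.

Measured in a physicochemical assay for lipophilicity, read by HPLC, at pH 7.4; on this read-out lower numbers stand for lower lipophilicity and higher numbers for higher lipophilicity:
- Compound 1 `CCC/N=C1\S/C(=C\c2ccc(O)c(C(F)(F)F)c2)C(=O)N1c1ccccc1C`: 3.8
- Compound 2 `CCC/N=C1\S/C(=C\c2ccc(O)c(C(C)C)c2)C(=O)N1c1ccccc1C`: 4.3

Compound 2 stands higher of the two, with compound 1 the nearest value below it. Compound 3 `CCC/N=C1\S/C(=C\c2ccc(O)c(Br)c2)C(=O)N1c1ccccc1C` has bromo in place of isopropyl on an aromatic carbon. Within the data shown here, only one measured step bears on this change: a number 0.50 log units higher from compound 1 to compound 2 (beyond the scatter), a modest rise that came with isopropyl in place of trifluoromethyl. Here isopropyl leaves instead, so a fall of similar size is expected in this assay, although no bromo compound has been measured yet. The expected change is a number 0.50 log units lower from compound 2 to compound 3 (beyond the scatter). For compound 3 the estimated value is 3.8, with an expected range of 3.4 to 4.2.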

Compound 3, distribution coefficient: 3.9
Compound 3: middle estimate off by 0.10 log units, on the low side; the measured number falls inside the stated range.
By their numbers in this assay, from the lowest: compounds 1 and 3 (each within the scatter of the next); then compound 2.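

In this assay, bromo in place of isopropyl, ortho to a hydroxy group, gives a clear fall (a number 0.40 log units lower from compound 2 to compound 3 (beyond the scatter)), so this position responds when one bromine atom replaces three carbons. Bromo in place of trifluoromethyl gives no difference that can be separated from the scatter (a number 0.10 log units higher from compound 1 to compound 3 (within the scatter)), which leaves isopropyl apart from the other two groups. No available evidence gives a reason for these results.

From the compounds shown here alone, whether a methyl, a methoxy or an amine here would sit with bromo and trifluoromethyl or with isopropyl stays open. So does whether these steps would hold on a different core.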